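A few compounds are considered here, and "the series" means these few. Any claim that something is new, unique, unknown or untested is made for them only; others in the source may bear on it.

Compound 1 `Cn1c(=O)c(S(=O)(=O)Cc2ccc(F)cc2)cc2cnc(Nc3ccc4[nH]ccc4c3)nc21` gives 30000 nM in a functional assay on DU-145 cells (Homo sapiens) for inhibition, read by trypan blue exclusion, with a stated time of 72 h; on this read-out higher numbers stand for weaker inhibition and lower numbers for stronger inhibition. Compound 2 `Cc1ccc(S(=O)(=O)c2cc3cnc(Nc4ccc5[nH]ccc5c4)nc3n(C)c2=O)cc1` gives 750 nM. Compound 3 `Cc1ccc(S(=O)(=O)c2cc3cnc(Nc4ccc5cc[nH]c5c4)nc3n(C)c2=O)cc1` gives 15000 nM.

Among these three, compound 2 stands with the lowest number: a 40-fold lower number from compound 1 to compound 2 (1.60 log units; beyond the scatter) and a 20-fold higher number from compound 2 to compound 3 (1.30 log units; beyond the scatter) both lie beyond the scatter, and both are large. Compound 4 `Cn1c(=O)c(C(=O)Nc2ccc(F)cc2)cc2cnc(Nc3ccc4[nH]ccc4c3)nc21` differs from compound 2 at one place: (4-fluorophenyl)carbamoyl in place of (4-methylphenyl)sulfonyl on an aromatic carbon. The measured step that bears on this place is a 40-fold lower number from compound 1 to compound 2 (1.60 log units; beyond the scatter), which shows that the group on this aromatic carbon can move the number very far, and that the (4-methylphenyl)sulfonyl group of compound 2 gave the lowest number seen. Going by the values given here, no measured step involves a (4-fluorophenyl)carbamoyl group, so the direction for compound 4 cannot be read from a matching pair; the size of the step at this position, however, argues for a large movement, and since compound 2 already holds the lowest number, a higher number for compound 4 is expected. Compound 4 is therefore expected to give 8000 nM, with a range from 1500 nM to 40000 nM, that is a step of an 11-fold higher number from compound 2 to compound 4 (1.03 log units; beyond the scatter).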

Compound 4, half-maximal inhibitory concentration: 5000 nM
For compound 4 the middle estimate is 1.6-fold (0.20 log units) above the measured one, and the stated range covers the measured number.
By their numbers in this assay, from the lowest: compound 2; then compound 4; then compounds 3 and 1 (each within the scatter of the next).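

In this assay, the aromatic carbon now carries a group joined through a carbonyl rather than a sulfonyl, and the change from (4-methylphenyl)sulfonyl to (4-fluorophenyl)carbamoyl gives a 6.7-fold higher number from compound 2 to compound 4 (0.82 log units; beyond the scatter). Against the (4-fluorobenzyl)sulfonyl group, the same (4-fluorophenyl)carbamoyl group gives a 6.0-fold lower number from compound 1 to compound 4 (0.78 log units; beyond the scatter), so it falls between the two sulfonyl groups, with both steps modest and beyond the scatter, and a sulfonyl link alone does not fix the number at this position. Nothing measured here accounts for this order.

On these data alone, the link and the group on the phenyl ring change together from compound 2 to compound 4, so their separate shares remain open, and a (4-methylphenyl)carbamoyl group would bear on that. As far as these compounds go, how a carboxylic acid or a simple amine on this carbon would compare also remains open.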